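Compound 4 against compound 3: same atoms, undrawn geometry

A few compounds are considered here, and "the series" means these few. Any claim that something is new, unique, unknown or untested is made for them only; others in the source may bear on it.

Compound 1 `C/C(=N/NC(=S)Nc1ccccc1I)c1ccccn1`, compound 2 `CC(=NNC(=S)Nc1ccccc1F)c1ccccn1` and compound 3 `C/C(=N/NC(=S)Nc1ccc(Cl)cc1)c1ccccn1` have been tested in a functional assay on U-87MG ATCC cells (Homo sapiens) for cytotoxicity, read by MTT assay, with a stated time of 48 h; on this read-out lower numbers stand for stronger inhibition and higher numbers for weaker inhibition. In this assay compound 1 gives 6.1 nM, compound 2 gives 5 nM, and compound 3 gives 1.7 nM. Compound 3 therefore carries the lowest number of the three, and its distance from both compound 2 and compound 1 lies beyond the usual scatter, so it is the most potent of the measured set on this read-out.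

Compound 4 `CC(=NNC(=S)Nc1ccc(Cl)cc1)c1ccccn1` is the next entry for this assay. Set against compound 3, the difference is the two compounds have the same atoms and bonds; at least one stereo element is drawn with a configuration in one of them and without one in the other: 1 of 1 stereo elements differ; a double bond is drawn Z in compound 3 and without a configuration in compound 4. Among the compounds with values here, no step between measured compounds matches this change, and the two structures share every atom and every bond; only the way the double bond is drawn differs. The expectation is that the number does not move, with the estimated step being no change at the digits printed from compound 3 to compound 4 (within the scatter), none beyond the scatter. Compound 4 is accordingly expected to give about 1.7 nM, with a range from 0.8 nM to 3.6 nM.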

Compound 4, half-maximal inhibitory concentration: 1.7 nM
Compound 4: middle estimate and measured number agree at the digits printed, and the stated range covers the measured number.
By their numbers in this assay, from the lowest: compounds 3 and 4 (each within the scatter of the next); then compounds 2 and 1 (each within the scatter of the next).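

In this assay, within the data shown here, the series gains its first step between measured compounds, no change at the digits printed from compound 3 to compound 4 (within the scatter), and this gives a reading on the drawn geometry of the double bond that the earlier compounds, with no step among them, could not give. With or without a drawn configuration, the number stays in place for this pair, so the two entries read as near duplicates on this read-out, and the only difference between them is one of depiction: the fact that one of compounds 3 and 4 is drawn with a defined configuration and the other without, at the place where they differ. This is not a comparison of two defined geometries, as compound 4 carries no stated configuration.

The compounds shown leave open how the opposite defined geometry at this double bond would read. Also open, going by these compounds, is what an amine or a carboxylic acid would give in place of the halogen of compound 3.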